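Boc-protected alkynyl amino-alcohol analogues: sphingosine kinase 1 inhibition

The source may hold more compounds than are shown below. What is called first, only, known or untested is meant among the compounds shown, and "the series" means these compounds.

Measured so far:
compound 1 `CCCCCCCCC#C[C@@H](O)[C@@H](N)CO` — 13.7%
compound 2 `CCCCC#C[C@H](O)[C@H](CO)NC(=O)OC(C)(C)C` — "not active" (no number reported)
compound 3 `CCCCC#CC(=O)[C@H](CO)NC(=O)OC(C)(C)C` — "not active" (no number reported)

In an assay on CHO cells for inhibition of sphingosine kinase 1 (Homo sapiens), tested at 10 uM (on this read-out higher numbers stand for more inhibition at the one concentration tested (going by the name of the read-out) and lower numbers for less inhibition), compound 1 gives 13.7%. Compound 2, with the protected amine and the shorter chain, is reported in this assay as "not active" (no number reported). The ketone counterpart of compound 2 is compound 3, which is likewise reported in this assay as "not active" (no number reported); no number stands behind that entry, so compound 3 cannot be placed on the same scale as compound 1, and the only thing its entry shows is that it did not register as active.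

The next compound is compound 4 `CCCCCCCCC#CC(=O)[C@H](CO)NC(=O)OC(C)(C)C`. It differs from compound 3 by butyl in place of hydrogen on a saturated chain carbon, four bonds along the chain from a triple-bonded carbon. Within the data shown here, no pair has a computed step in this assay from which to read a size for this change, and the one compound with a number, compound 1, sits low. The expectation for compound 4 is therefore a small read-out, with a real chance that it is again reported without a number. Compound 4 is estimated at 10% in this assay, with a range of 0% to 25%.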

Compound 4, a percentage reported as inhibition, at one concentration (the size of the read-out at that concentration, not a potency): 4.2%
Compound 4: the middle estimate sits 5.8 percentage points above what was measured, within the range that was stated.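

In this assay compound 4 gives 4.2% while compound 3 stands only as "not active", so no step can be read between compound 3 and compound 4. As far as these compounds go, whether butyl in place of hydrogen shifts this read-out stays open. No measured evidence bears on this result.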